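Bromo for Methyl at the Cytotoxicity Ceiling

The source may hold more compounds than are shown below. What is called first, only, known or untested is meant among the compounds shown, and "the series" means these compounds.

Measured compounds:
compound 1, `Cc1ccc(-c2nn(-c3ccccc3)cc2CNc2ccccc2)cc1`, gives > 100000 nM in an ADME assay on BHK-21 cells (Mesocricetus auratus) for cytotoxicity, read by MTT assay, with a stated time of 72 h; a lower number here means that less compound is tolerated, a higher number that more compound is tolerated.
compound 2, `Cc1ccc(-c2nn(-c3ccccc3)cc2CNc2ccc(C(F)(F)F)cc2)cc1`, gives 88000 nM.
compound 3, `Cc1ccc(-c2nn(-c3ccccc3)cc2CNc2ccc(Cl)cc2)cc1`, gives > 100000 nM.

Compound 1 stands at a limit of this assay rather than at a number. Compound 3 likewise reports only a limit. For the measured compounds named here, compound 2 is the one compound of the three with a number. The measured steps all sit on the aniline ring: an at least 1.1-fold lower number from compound 1 to compound 2 (0.05 log units; that floor lies within the scatter), an at least 1.1-fold higher number from compound 2 to compound 3 (0.05 log units; that floor lies within the scatter), and a step that the two limits leave unreadable from compound 1 to compound 3. That the two limits leave the last step unreadable follows from the limit of > 100000 nM in this assay, at which 2 of the 3 values shown sit.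

Compound 4, `Brc1ccc(-c2nn(-c3ccccc3)cc2CNc2ccccc2)cc1`, differs from compound 1 elsewhere: bromo in place of methyl on an aromatic carbon. Going by the values given here, no measured step touches that ring, so none bears directly on this change. The steps that are readable stay within the scatter, and two of the three values rest at the limit, so a step of no size beyond the scatter is expected here, with compound 4 expected to report a limit again. Compound 4 is therefore estimated at 100000 nM, between 50000 nM and 200000 nM. The expected step is a number no higher from compound 1 to compound 4 (the limit leaves the size open), judged to lie within the scatter.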

Compound 4, half-maximal cytotoxic concentration: > 100000 nM
Compound 4 gave a limit, no number; the forecaster's own chance of this, stated with the estimate: 70%; the middle value sits exactly at the limit.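

In this assay compound 4 gives > 100000 nM, which is a limit and not a number. For the compounds shown here, compound 1 also stands at a limit, so no step from compound 1 to compound 4 can be read: the limit of > 100000 nM in this assay, at which 3 of the 4 values shown sit. The compounds shown leave open what size, if any, the change from 4-methylphenyl to 4-bromophenyl has in this assay.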